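Trimethoxyphenyl swap on compound 3

The source may hold more compounds than are shown below. What is called first, only, known or untested is meant among the compounds shown, and "the series" means these compounds.

In a functional assay on MOLT-3 cells (Homo sapiens) for cytotoxicity, read by XTT assay, with a stated time of 48 h (on this read-out lower numbers stand for stronger inhibition and higher numbers for weaker inhibition), compound 3 (`COc1ccc(/C=C/C(=O)c2ccc(-n3cc(COc4ccc5ccc(=O)oc5c4)nn3)cc2)c(OC)c1OC`) gives 22500 nM, the highest number of the three measured. Compound 1 (`COc1ccc(/C=C/C(=O)c2cccc(-n3cc(COc4ccc5ccc(=O)oc5c4)nn3)c2)cc1OC`) gives 3120 nM and compound 2 (`COc1cccc(/C=C/C(=O)c2cccc(-n3cc(COc4ccc5ccc(=O)oc5c4)nn3)c2)c1OC`) gives 5160 nM in the same assay. Both of these numbers lie beyond the scatter from that of compound 3. The change to compound 4 (`COc1cc(/C=C/C(=O)c2ccc(-n3cc(COc4ccc5ccc(=O)oc5c4)nn3)cc2)cc(OC)c1OC`) is 3,4,5-trimethoxyphenyl in place of 2,3,4-trimethoxyphenyl on a double-bonded chain carbon bound to a double-bonded chain carbon with the same atoms joined differently. Going by the values given here, the only measured step that rearranges methoxy groups on the phenyl is a 1.7-fold higher number from compound 1 to compound 2 (0.22 log units; within the scatter) and it comes from a core that differs from that of compound 3. No step beyond the scatter is therefore expected in this assay and no direction is favoured. The estimated step is a 1.1-fold lower number from compound 3 to compound 4 (0.05 log units; within the scatter) and remains uncertain. For compound 4 the expected value is 20000 nM (estimated range 7000 nM to 55000 nM).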

Compound 4, half-maximal inhibitory concentration: 79500 nM
Estimate against measurement, compound 4: 4.0-fold (0.60 log units) below; measured number outside the range, above it.
By their numbers in this assay, from the lowest: compounds 1 and 2 (each within the scatter of the next); then compound 3; then compound 4.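

In this assay the arrangement of methoxy groups on the phenyl matters on the core of compound 3: 3,4,5-trimethoxyphenyl in place of 2,3,4-trimethoxyphenyl gives a 3.5-fold higher number from compound 3 to compound 4 (0.55 log units; beyond the scatter). Going by these compounds alone, the one earlier rearrangement, on a different core, stayed within the scatter, so this is the first step beyond it for such a change. No measurement shown accounts for this step. Still open, going by these compounds, is whether the same two arrangements keep this order on the core of compound 1, and whether an amine or a carboxylic acid on the phenyl would give a lower number.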